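The source may hold more compounds than are shown below. What is called first, only, known or untested is meant among the compounds shown, and "the series" means these compounds.

Of the compounds shown here, two have been measured so far. Compound 1 `CN1CCC(OC(=O)c2ccc(C(C)(C)C)cc2)CC1` and compound 2 `CN1CCC(OC(=O)c2ccc(Cl)cc2)CC1` share one core and differ only in the group on an aromatic carbon. In a functional assay on the whole organism with Mus musculus as the target (a higher number here means a more potent compound, by a factor of ten per unit of this negative logarithm, a lower number a less potent compound), compound 1 gives 1.13, and in the same assay compound 2 gives 1.11. The step of a number 0.02 log units lower from compound 1 to compound 2 (within the scatter) shows that exchanging tert-butyl for chloro changed almost nothing. Compound 2 therefore stands level with compound 1, the two values lying within the usual scatter of each other.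

Compound 3 `CN1CCC(OC(=O)c2ccc(F)cc2)CC1` is the next compound, not yet measured. Its difference from compound 2 is fluoro in place of chloro on an aromatic carbon. For the measured compounds named here, only one measured step bears on this kind of change, and that step left the number essentially where it was, so a comparable outcome is the natural expectation here. The estimated step from compound 2 to compound 3 is a number 0.06 log units lower from compound 2 to compound 3 (within the scatter). Compound 3 is thus expected to give about 1.05, with a likely range from 0.75 to 1.4.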

Compound 3, logarithm of the reciprocal of the active concentration, log(1/C): 1.38
Estimate against measurement, compound 3: 0.33 log units below; the measured number falls inside the stated range.
By their numbers in this assay, from the lowest: compounds 2, 1 and 3 (each within the scatter of the next).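

In this assay fluoro in place of chloro gives one step (a number 0.27 log units higher from compound 2 to compound 3 (within the scatter)) and fluoro in place of tert-butyl gives another (a number 0.25 log units higher from compound 1 to compound 3 (within the scatter)). Tert-butyl, chloro and fluoro on this aromatic carbon therefore all lie within the usual scatter of one another, so the compounds shown reveal no clear preference among these three groups at this position. No available evidence bears on why these numbers lie so close together.

The compounds shown leave open whether a group of another kind at this position, such as an amine or a carboxylic acid, would move the number beyond the scatter. They also leave open what a hydrogen in place of these groups would give, which would show whether having any group here matters at all.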